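This account rests on a few compounds, and the source may have more. Where it says the series, first, only, none or still open, it means among the compounds named here.

Among the measured compounds shown here, compound 1 `CCC[C@@H]1O[C@H](COCc2ccccc2)[C@@H](OCc2ccccc2)[C@H](OCc2ccccc2)[C@H]1O` is the only compound here with a number of its own: in a functional assay on HOS cells (Homo sapiens) for antiproliferative activity, read by sulforhodamine B assay (a lower number here means a stronger inhibitor of growth, a higher number a weaker inhibitor of growth), compound 1 gives 38600 nM. Compound 2 `CCC[C@@H]1O[C@H](COCc2ccccc2)[C@@H](OCc2ccccc2)[C@H](OCc2ccccc2)[C@@H]1O` reaches only a limit of this assay, > 50000 nM. The step of an at least 1.2-fold higher number from compound 1 to compound 2 (0.11 log units; that floor lies within the scatter) is a bare inversion of configuration and carries no information about a change of groups. Compound 3 `OC[C@@H]1O[C@H](COCc2ccccc2)[C@@H](OCc2ccccc2)[C@H](OCc2ccccc2)[C@H]1O` differs from compound 1 by hydroxy in place of ethyl on a saturated chain carbon bound to a saturated ring carbon. For the measured compounds named here, no measured step involves a change of this kind, so no shift beyond the scatter is expected, and the expected step is a 1.0-fold higher number from compound 1 to compound 3 (0.02 log units; within the scatter). Compound 3 is therefore estimated at 40000 nM, with a range from 15000 nM to 100000 nM.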

Compound 3, concentration for 50% growth inhibition: 27300 nM
For compound 3 the middle estimate is 1.5-fold (0.17 log units) above the measured one; the range from low to high includes it.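

In this assay hydroxy in place of ethyl on a saturated chain carbon bound to a saturated ring carbon gives a 1.4-fold lower number from compound 1 to compound 3 (0.15 log units; within the scatter) and so no shift beyond the scatter. Among the compounds shown here, this is the first change of group read at this place, and the shared core keeps its modest level of growth inhibition whether ethyl or hydroxy stands there. Nothing given here bears on why this is so.

Going by these compounds, whether an amine, a carboxylic acid or a longer chain at this place would shift the number remains open. So does whether hydroxy would behave the same way in the inverted configuration of compound 2.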